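This account rests on a few compounds, and the source may have more. Where it says the series, first, only, none or still open, it means among the compounds named here.

Measured so far in an ADME assay on CEM-SS cells (Homo sapiens) for cytotoxicity, read by XTT assay; a lower number here means that less compound is tolerated, a higher number that more compound is tolerated:
- compound 1 `COCCOCc1cn(Cc2ccc(F)cc2)c2cnc(C(=O)N(C)O)cc12`: > 100000 nM (a limit, not a number)
- compound 2 `COCc1cn(Cc2ccc(F)cc2)c2cnc(C(=O)N(C)O)cc12`: 266000 nM
- compound 3 `CCOCCOCc1cn(Cc2ccc(F)cc2)c2cnc(C(=O)N(C)O)cc12`: 81000 nM

Compound 3 has the lower of the two true numbers in this assay, and its nearest neighbour is compound 2, with a gap of a 3.3-fold lower number from compound 2 to compound 3 (0.52 log units; beyond the scatter). For compound 1 the reading is a limit: the limit of > 100000 nM in this assay, at which 1 of the 3 values shown sits. That leaves a step that the limit leaves unreadable from compound 1 to compound 2, and an at least 1.2-fold lower number from compound 1 to compound 3 (0.09 log units; that floor lies within the scatter) gives only a floor.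

Compound 4 `CN(O)C(=O)c1cc2c(CCCO)cn(Cc3ccc(F)cc3)c2cn1` replaces the side chain of compound 3: 2-hydroxyethyl in place of 2-ethoxyethoxy on a saturated chain carbon bound to an aromatic carbon. In words, this is 2-hydroxyethyl in place of 2-ethoxyethoxy on a saturated chain carbon bound to an aromatic carbon, or, cut one bond further out, (2-ethoxyethoxy)methyl to 3-hydroxypropyl.

Within the data shown here, no measured step introduces a hydroxyl group, so the steps bear on this change only in part. Among the measured compounds shown here, the one readable guide is compound 2, where a 3.3-fold lower number from compound 2 to compound 3 (0.52 log units; beyond the scatter) accompanies the gain of ethoxymethyl. For the measured compounds named here, compound 4 also carries a smaller group than compound 3, so a modest rise is expected, no larger than that step and possibly within the scatter. The expected step is a 1.9-fold higher number from compound 3 to compound 4 (0.27 log units; within the scatter). For compound 4 the estimate is 150000 nM, with an expected range of 60000 nM to 350000 nM.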

Compound 4, half-maximal cytotoxic concentration: > 10000 nM
Compound 4 was reported as a limit; the forecaster's own chance of this, stated with the estimate: 35%; the middle value is on the limit's open side.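

In this assay compound 4 gives > 10000 nM, which is a limit and not a number. None of the steps from compound 1, compound 2 or compound 3 to compound 4 can be read. The compounds shown leave open where compound 4, with its 3-hydroxypropyl chain, stands relative to compound 2 and compound 3 in this assay.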